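A few compounds are considered here, and "the series" means these few. Any claim that something is new, unique, unknown or untested is made for them only; others in the source may bear on it.

Measured compounds:
compound 1, `CC(C)C[C@H](NC(=O)OCc1ccccc1)C(=O)NCCNc1ccc(OC2CCCCC2)cc1` — 1200 nM
compound 2, `CC(C)C[C@H](NC(=O)OCc1ccccc1)C(=O)NCCNc1ccc(OCCn2ccnc2)cc1` — 5700 nM

Within the data shown here, of the two numbers so far in an assay on isolated protein for inhibition of cathepsin S (Homo sapiens) (a lower number here means a stronger inhibitor, a higher number a weaker inhibitor), compound 2 carries the higher one; its nearest neighbour is compound 1, and the change between them is a 4.8-fold higher number from compound 1 to compound 2 (0.68 log units; beyond the scatter), beyond the scatter. Compound 3, `CC(C)C[C@H](NC(=O)OCc1ccccc1)C(=O)NCCNc1ccc(Oc2ccccc2)cc1`, has not yet been measured. It differs from compound 2 by phenyl in place of 2-(1H-imidazol-1-yl)ethyl on an oxygen on an aromatic ring. Among the measured compounds shown here, the only measured step at this place is the one where a 4.8-fold higher number from compound 1 to compound 2 (0.68 log units; beyond the scatter): there the 2-(1H-imidazol-1-yl)ethyl entered and the number rose. Compound 3 removes that group again and puts a ring of carbon only on the oxygen, which as a structure sits closer to the cyclohexyl of compound 1 than to the group it replaces. A lower number is therefore expected for compound 3, with a 3.8-fold lower number from compound 2 to compound 3 (0.58 log units; beyond the scatter) as the estimated step. Compound 3 is estimated at 1500 nM, within a range from 500 nM to 5000 nM.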

Compound 3, half-maximal inhibitory concentration: 5800 nM
Estimate against measurement, compound 3: 3.9-fold (0.59 log units) below; the measured number lies above the stated range.
By their numbers in this assay, from the lowest: compound 1; then compounds 2 and 3 (each within the scatter of the next).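

In this assay the step of a 1.0-fold higher number from compound 2 to compound 3 (0.01 log units; within the scatter) shows that, on this oxygen on an aromatic ring, phenyl and 2-(1H-imidazol-1-yl)ethyl cannot be told apart, although one is a six-membered ring of carbon only and the other holds a five-membered ring with hetero atoms. The step of a 4.8-fold higher number from compound 1 to compound 3 (0.68 log units; beyond the scatter) shows that an aromatic ring of carbon only does not keep the number of compound 1, so among these three groups cyclohexyl alone stands apart, and it gives the strongest inhibitor of the three. Nothing available explains why cyclohexyl differs from the other two groups.

The compounds shown leave open whether other saturated groups on this oxygen, such as cyclopentyl, cycloheptyl or an open isobutyl chain, would match or pass cyclohexyl. They also leave open how a 2-(dimethylamino)ethyl chain or a carboxylic acid would read at this place.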